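The compounds below may be only part of what the source reports. "The series", "measured", "known", "first", "only" and "open" are said of these compounds alone.

Measured so far in a functional assay on the whole organism (stomach) with Rattus norvegicus as the target; on this read-out higher numbers stand for an effect only at larger amounts of compound and lower numbers for an effect already at smaller amounts:
compound 1, `CCC/N=C(/NC#N)NCCCCCn1nc(-c2ccccc2)ccc1=O`, > 100 mg/kg
compound 2, `CC(C)C/N=C(\S)NCCCCn1nc(-c2ccccc2)ccc1=O`, > 100 mg/kg

Two compounds of the series have been run in this assay. Compound 1 gives > 100 mg/kg, which is a limit of the assay and not a number. Compound 2 gives > 100 mg/kg, again a limit rather than a measured dose. For the measured compounds named here, compound 2 therefore cannot be placed on a scale of numbers: both values so far sit at the same limit (the limit of > 100 mg/kg in this assay, at which 2 of the 2 values shown sit), and no step between measured compounds can be drawn from them.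

Compound 3 `N/C(S)=N/CCCCn1nc(-c2ccccc2)ccc1=O` is the next to be measured in this assay. It differs from compound 2 in one place: a group of 4 heavy atoms (1 carbon, 2 nitrogen, 1 sulfur; no ring) in place of a group of 8 heavy atoms (5 carbon, 2 nitrogen, 1 sulfur; no ring), on a saturated chain carbon, four bonds along the chain from an aromatic nitrogen. Going by the values given here, with both measured compounds at the limit there is no measured step to lean on. The step that the estimate below means is a step that the limit leaves unreadable from compound 2 to compound 3, expected to be none beyond the usual scatter. For compound 3 in this assay the expected dose is 200 mg/kg, with a range from 60 mg/kg to 600 mg/kg, and it is expected that the assay will most likely again report only a limit.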

Compound 3, dose for half-maximal effect: 36.3 mg/kg
The estimate for compound 3 lay 5.5-fold (0.74 log units) above the measured number; measured number outside the range, below it.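

In this assay the series now holds its first readable number, and it comes from a change on a saturated chain carbon, four bonds along the chain from an aromatic nitrogen. Putting the group of 4 heavy atoms in place of the group of 8 heavy atoms gives an at least 2.7-fold lower number from compound 2 to compound 3 (0.44 log units; beyond the scatter), so the read-out does respond to what this position carries, even though both groups have the same hydrogen-bond donor and acceptor counts. The size of this step is only a lower bound, since compound 2 sits at a limit of the assay and not at a number: the limit of > 100 mg/kg in this assay, at which 2 of the 3 values shown sit.

Compound 1 differs from compound 3 in more than one place, so no step can be read between them, and the shown compounds cannot separate the size of the group from any other difference between the two groups. Also open, on these data alone, is whether the dose shifts gradually with group size at this position, and how a guanidine, an amine or a longer chain in the same place would read out in this assay.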